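Swapping the Ester Tail: What Cell Tolerance to Expect

The source may report more compounds than this note shows. Statements on the series, on what has been measured and on what is new or still open speak of the compounds shown alone.

Of the compounds shown here, three built on one shared core have been measured in an ADME assay on HepG2 2.2.15 cells (Homo sapiens) for cytotoxicity; a lower number here means that less compound is tolerated, a higher number that more compound is tolerated.

Compound 1, `Cn1c(=O)c(CCO)c(-c2ccccc2Cl)c2cc(Cl)ccc21`, gives 34000 nM.
Compound 2, `CC(=O)OCCc1c(-c2ccccc2Cl)c2cc(Cl)ccc2[nH]c1=O`, gives 27000 nM.
Compound 3, `CC(=O)N1CCC(C(=O)OCCc2c(-c3ccccc3Cl)c3cc(Cl)ccc3[nH]c2=O)CC1`, gives 82000 nM.

Compound 3 stands highest of the three, so it is the best tolerated; its gap to compound 1 and its gap to compound 2 both lie beyond the usual scatter.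

Compound 4, `O=C(/C=C/c1cccnc1)OCCc1c(-c2ccccc2Cl)c2cc(Cl)ccc2[nH]c1=O`, has not yet been measured. It differs from compound 3 in one place: 2-(pyridin-3-yl)ethenyl in place of 1-acetylpiperidin-4-yl on a carbonyl carbon. Within the data shown here, only one measured step touches this position, a 3.0-fold higher number from compound 2 to compound 3 (0.48 log units; beyond the scatter), in which the 1-acetylpiperidin-4-yl group came in. Among the measured compounds shown here, compound 4 removes that group again, so part of that gain is expected to be given back, while the 2-(pyridin-3-yl)ethenyl group that enters appears in no measured compound, so no step guides its own contribution. A modest downward step is therefore expected, a 2.1-fold lower number from compound 3 to compound 4 (0.31 log units; beyond the scatter). Compound 4 is expected to give about 40000 nM, within a range from 15000 nM to 100000 nM.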

Compound 4, half-maximal cytotoxic concentration: 39000 nM
Compound 4: middle estimate off by 1.0-fold (0.01 log units), on the high side; low and high end bracket the measured number.
By their numbers in this assay, from the lowest: compounds 2, 1 and 4 (each within the scatter of the next); then compound 3.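

In this assay, 2-(pyridin-3-yl)ethenyl in place of 1-acetylpiperidin-4-yl gives a 2.1-fold lower number from compound 3 to compound 4 (0.32 log units; beyond the scatter) and so shows that the high number of compound 3 does not carry over to every group bigger than methyl on this carbonyl carbon. Set against the methyl group, the same 2-(pyridin-3-yl)ethenyl group gives a 1.4-fold higher number from compound 2 to compound 4 (0.16 log units; within the scatter) and so no real change, which leaves 1-acetylpiperidin-4-yl as the only one of these three groups that stands apart. No measurement here explains the difference between these groups.

Going by these compounds, it remains open whether the higher number of compound 3 depends on the acetyl group or on the piperidine ring itself, which a piperidin-4-yl group without the acetyl would test. Also open, on these data alone, is what an amine, a carboxylic acid or a longer plain carbon chain would give at this position.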